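A few compounds are considered here, and "the series" means these few. Any claim that something is new, unique, unknown or untested is made for them only; others in the source may bear on it.

In an assay on HEK293 cells for inhibition of transient receptor potential cation channel subfamily V member 1 (Homo sapiens), read by FLIPR, at pH 5.5 (on this read-out higher numbers stand for weaker inhibition and lower numbers for stronger inhibition), compound 2 `Cc1cc(N2CCN(C(=O)Nc3ccc(OC(F)(F)F)cc3)CC2)nnc1Cl` gives only a limit of the assay, > 10000 nM. Compound 1 `Cc1cc(N2CCN(C(=O)Nc3ccc(C(C)C)cc3)CC2)nnc1Cl` likewise gives a limit in this assay, > 10000 nM. The step that the two limits leave unreadable from compound 1 to compound 2 is therefore unreadable, due to the limit of > 10000 nM in this assay, at which 2 of the 2 values shown sit. Compound 3 `O=C(Nc1ccc(OC(F)(F)F)cc1)N1CCN(c2nncc3ccccc23)CC1` differs from compound 2 by a group of 10 heavy atoms (8 carbon, 2 nitrogen; one six-membered aromatic ring of carbon only, one six-membered aromatic ring with 2 hetero atoms) in place of a group of 8 heavy atoms (5 carbon, 2 nitrogen, 1 chlorine; one six-membered aromatic ring with 2 hetero atoms), on an amine nitrogen in a ring. No measured step touches that change, and the one measured step has no readable size, so neither direction nor size can be drawn from the numbers shown. Compound 3 is therefore estimated at 10000 nM, between 2000 nM and 50000 nM. The expected step of a number no higher from compound 2 to compound 3 (the limit leaves the size open) is thus one not beyond the scatter.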

Compound 3, half-maximal inhibitory concentration: > 10000 nM
Compound 3: only a limit was reported (the forecaster's own chance of this, stated with the estimate: 70%); the middle value lies on the limit itself.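

For the compounds shown here, compound 2 and compound 3 both give only a limit, so no step between them can be read: the limit of > 10000 nM in this assay, at which 3 of the 3 values shown sit. How strongly any of these compounds inhibits the channel, and whether replacing 6-chloro-5-methylpyridazin-3-yl changes that, remains open.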